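The source may hold more compounds than are shown below. What is called first, only, known or untested is meant among the compounds shown, and "the series" means these compounds.

Measured so far:
- compound 1 `CC(C)(C)c1cccc(C2CNCC2C(=O)Nc2cc3cc[nH]c(=O)c3cc2Cl)c1`: "not determined" (no result reported)
- compound 2 `O=C(Nc1cc2cc[nH]c(=O)c2cc1Cl)[C@@H]1CCCNC1`: 550 nM
- compound 3 `Cc1cccc(C2CNCC2C(=O)Nc2cc3cc[nH]c(=O)c3cc2Cl)c1`: "not determined" (no result reported)

Compound 1 stands without a number in a functional assay on aorta (Rattus norvegicus) for inhibition; a higher number here means a weaker inhibitor, a lower number a stronger inhibitor; compound 3 is in the same position. Among the measured compounds shown here, the only value belongs to compound 2, which gives 550 nM in this assay. Compound 2 carries the shared core on a different saturated ring and has no aryl substituent, so it offers no direct read on how compound 1 behaves.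

Compound 4 `O=C(Nc1cc2cc[nH]c(=O)c2cc1Cl)C1CNCC1c1cccc(Br)c1` is the next entry to be measured in this assay. It differs from compound 1 in one place: bromo in place of tert-butyl on an aromatic carbon. For the measured compounds named here, no step between measured compounds is available to anchor the size of this change, and compound 1 itself has no value, so the direction of the step cannot be judged beyond stating that a change of this kind could fall within the scatter or somewhat beyond it in either direction.

With compound 2 as the only reference point in this assay, compound 4 is expected to give roughly 300 nM, within a range of 40 nM to 3000 nM.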

Compound 4, half-maximal inhibitory concentration: 63 nM
Compound 4: the middle estimate sits 4.8-fold (0.68 log units) above what was measured; low and high end bracket the measured number.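

Among the compounds shown here, with compound 1 at "not determined" (no result reported) in this assay and compound 4 at 63 nM there, no step between the two can be read. On these data alone, what remains open is how 3-(tert-butyl)phenyl and 3-bromophenyl compare on the shared core in this assay for this series. No further data bear on this result.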